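A few compounds are considered here, and "the series" means these few. Any claim that something is new, unique, unknown or untested is made for them only; others in the source may bear on it.

Within the data shown here, only two compounds have numbers so far. In a functional assay on HeLa cells (Homo sapiens) for cytotoxicity, read by MTT assay, with a stated time of 72 h (on this read-out higher numbers stand for weaker inhibition and lower numbers for stronger inhibition), compound 2 (`O=[N+]([O-])c1ccc(/N=N/Nc2ccc([N+](=O)[O-])cc2Br)c(Br)c1`) gives 940 nM, the lower of the two numbers. Compound 1 (`CC(=O)Oc1ccc(/C=C/C(=O)N(/N=N/c2ccc(Cl)c(C(F)(F)F)c2)c2ccc(Cl)c(C(F)(F)F)c2)cc1OC(C)=O`) gives 43000 nM, and the gap between them lies well beyond the scatter.

The next compound to be tested is compound 3 (`O=C(c1ccc(F)cc1)N(/N=N/c1ccc([N+](=O)[O-])cc1Br)c1ccc([N+](=O)[O-])cc1Br`), which differs from compound 2 at one place: (4-fluorophenyl)carbonyl in place of hydrogen on a nitrogen on an aromatic ring. In words, (4-fluorophenyl)carbonyl stands in place of hydrogen on a nitrogen on an aromatic ring.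

Among the measured compounds shown here, no measured pair isolates this change, so the size of the step cannot be read directly from the data. For the measured compounds named here, the only guide is compound 1, which also has a carbonyl on such a nitrogen and reads 43000 nM. This single number points toward weaker inhibition, but it cannot fix the size of the move, and the two rings of compound 2 are kept in compound 3.

In this assay the expected change is a 2.1-fold higher number from compound 2 to compound 3 (0.33 log units; beyond the scatter), a small move toward weaker inhibition, close to the scatter. For compound 3 the estimated value is 2000 nM, with an expected range of 400 nM to 10000 nM.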

Compound 3, half-maximal inhibitory concentration: 580 nM
For compound 3 the middle estimate is 3.4-fold (0.54 log units) above the measured one; the range from low to high includes it.
By their numbers in this assay, from the lowest: compounds 3 and 2 (each within the scatter of the next); then compound 1.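

In this assay the replacement of hydrogen by (4-fluorophenyl)carbonyl on a nitrogen on an aromatic ring gives a 1.6-fold lower number from compound 2 to compound 3 (0.21 log units; within the scatter), so this read-out does not separate the two compounds. Among these compounds, this is the first pair that isolates a change at this position, and it shows that a group of 9 heavy atoms, including a six-membered aromatic ring, can take the place of hydrogen on this nitrogen with the number remaining within the scatter of the parent. Nothing in hand on measured properties bears on this result, so the outcome stands as an observation without an explanation.

The compounds shown leave open whether the same holds for other groups on this nitrogen, such as acetyl, unsubstituted benzoyl, methyl or a longer alkyl chain. As far as these compounds go, compound 1 also carries a carbonyl on such a nitrogen but differs from compound 3 in more than one place, so it remains open whether the present result would carry over to the rings and the acyl group of compound 1.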